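Urea to Sulfonamide on the Side Chain of Compound 2

The source may report more compounds than this note shows. Statements on the series, on what has been measured and on what is new or still open speak of the compounds shown alone.

Measured compounds:
- compound 1, `NCC(=O)NC[C@@H]1CCCc2cc(S(=O)(=O)c3cccc(F)c3)ccc21` — 0.316 nM
- compound 2, `CN(C)C(=O)NC[C@@H]1CCCc2cc(S(=O)(=O)c3cccc(F)c3)ccc21` — 2.51 nM

The two compounds share one core and differ only in the group on the side-chain carbonyl. In an assay on isolated protein for displacement of a labelled ligand from 5-hydroxytryptamine receptor 6 (Homo sapiens) (on this read-out higher numbers stand for weaker inhibition and lower numbers for stronger inhibition), compound 1 gives 0.316 nM, while compound 2 gives 2.51 nM, and the step of a 7.9-fold higher number from compound 1 to compound 2 (0.90 log units; beyond the scatter) is modest. Compound 2 thus stands at the higher of the two numbers.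

Compound 3, `CN(C[C@@H]1CCCc2cc(S(=O)(=O)c3cccc(F)c3)ccc21)S(C)(=O)=O`, is not yet measured. It differs from compound 2 by methyl(methylsulfonyl)amino in place of (dimethylcarbamoyl)amino on a saturated chain carbon bound to a saturated ring carbon, so the whole (dimethylcarbamoyl)amino group leaves and a methyl(methylsulfonyl)amino group enters, and the single hydrogen-bond donor of that side chain is lost. Among the compounds with values here, no measured step covers this exact exchange; the only step at hand, a 7.9-fold higher number from compound 1 to compound 2 (0.90 log units; beyond the scatter), concerns a change on the carbonyl carbon and bears on it only loosely, showing that this side chain tolerates some variation with a modest shift. For compound 3 a modest weakening is therefore expected, a 2.4-fold higher number from compound 2 to compound 3 (0.38 log units; beyond the scatter), with wide uncertainty. The estimate for compound 3 is 6 nM, ranging from 1.2 nM to 30 nM.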

Compound 3, inhibition constant: 0.398 nM
For compound 3 the middle estimate is 15-fold (1.18 log units) above the measured one, outside the stated range (below it).
By their numbers in this assay, from the lowest: compounds 1 and 3 (each within the scatter of the next); then compound 2.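

In this assay the exchange of (dimethylcarbamoyl)amino for methyl(methylsulfonyl)amino on a saturated chain carbon bound to a saturated ring carbon gives a 6.3-fold lower number from compound 2 to compound 3 (0.80 log units; beyond the scatter) and so shows that this place tolerates more than changes on the carbonyl carbon: the carbonyl itself can go, along with the whole urea-type group, and the number still falls. Set against the other compound, the same group gives a 1.3-fold higher number from compound 1 to compound 3 (0.10 log units; within the scatter) and thus stands level with it, so a group with 0 hydrogen-bond donors reaches the low numbers of this short series, and a hydrogen-bond donor in the entering group is not needed for them. Nothing at hand explains why the sulfonyl-bearing group does better than the urea-type group of compound 2.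

On these data alone, the exchange alters the linking group and the methyl on its nitrogen together, so what the plain methylsulfonylamino group would give remains open and the share of each change cannot be separated. As far as these compounds go, it also remains open whether this place would hold its low number with a larger sulfonyl substituent, such as ethylsulfonyl or phenylsulfonyl, or with a carboxylic acid on the chain.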